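Adding an Amino Group to the Pyridine of Compound 3

The compounds below may be only part of what the source reports. "The series", "measured", "known", "first", "only" and "open" are said of these compounds alone.

Three measured compounds share one core and differ in a single group on an aromatic carbon. Compound 1 `O=c1ncn(Cc2c(F)cc(F)cc2F)c2ccc(Oc3cccc(-c4ccc5[nH]ccc5c4)c3C(F)(F)F)cc12` gives 5.1 in a physicochemical assay for lipophilicity, at pH 7.4; on this read-out higher numbers stand for higher lipophilicity and lower numbers for lower lipophilicity. Compound 2 `O=c1ncn(Cc2c(F)cc(F)cc2F)c2ccc(Oc3cccc(-c4ccc5[nH]cnc5c4)c3C(F)(F)F)cc12` gives 4.7, and compound 3 `Cc1ccc(-c2cccc(Oc3ccc4c(c3)c(=O)ncn4Cc3c(F)cc(F)cc3F)c2C(F)(F)F)cn1` gives 4.2, the lowest of the three. The measured steps were a number 0.40 log units lower from compound 1 to compound 2 (beyond the scatter), a number 0.90 log units lower from compound 1 to compound 3 (beyond the scatter) and a number 0.50 log units lower from compound 2 to compound 3 (beyond the scatter). Compound 4 `Cc1cc(-c2cccc(Oc3ccc4c(c3)c(=O)ncn4Cc3c(F)cc(F)cc3F)c2C(F)(F)F)cnc1N` has not yet been measured; it differs from compound 3 by 6-amino-5-methylpyridin-3-yl in place of 6-methylpyridin-3-yl on an aromatic carbon. Among the measured compounds shown here, each measured step replaced one ring group with another and lowered the number modestly, and no step adds an amino group, so a further modest drop is expected here, a number 0.70 log units lower from compound 3 to compound 4 (beyond the scatter). Compound 4 is therefore estimated at 3.5, within 3 to 4.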

Compound 4, distribution coefficient: > 4.7
Compound 4: a limit, no number; the forecaster's own chance of this, stated with the estimate: 0%; at least 1.20 log units between middle value and limit.
By their numbers in this assay, from the lowest: compound 3; then compound 2; then compound 1.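

In this assay compound 4 gives a limit and not a number: the limit of > 4.7 in this assay, at which 1 of the 4 values shown sits. Even so, the limit gives a number at least 0.50 log units higher from compound 3 to compound 4 (beyond the scatter), and this step runs opposite to the three earlier ring swaps, which all lowered the number. The limit also gives a number no lower from compound 2 to compound 4 (the limit leaves the size open). The step from compound 1 to compound 4 cannot be read.

The compounds shown leave open whether the amino group or the moved methyl carries this rise. On these data alone, how 6-aminopyridin-3-yl without the methyl, or a carboxylic acid in place of the amine, would read also stays open.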